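The compounds below may be only part of what the source reports. "The series", "measured", "known", "first", "only" and "open" are said of these compounds alone.

Of the compounds shown here, three sharing a two-part core have been measured in a functional assay; on this read-out higher numbers stand for weaker inhibition and lower numbers for stronger inhibition. Compound 1 `COc1ccc2oc(=O)cc(CSc3nnc(CSc4nc5ccccc5o4)o3)c2c1` gives 63.1 ug/mL in this assay. Compound 3 `COc1ccc2oc(=O)cc(CSc3nnc(CSc4nc5cc(Cl)ccc5o4)o3)c2c1` differs from compound 1 in one place, (chloro in place of hydrogen on an aromatic carbon), and in this assay compound 3 gives 52.9 ug/mL; the step of a 1.2-fold lower number from compound 1 to compound 3 (0.08 log units; within the scatter) does not rise above the usual scatter. Compound 2 `Cc1ccc2c(CSc3nnc(CSc4nc5ccccc5o4)o3)cc(=O)oc2c1` carries a different core; the difference between the two cores is not broken down here. In this assay compound 2 gives 49.9 ug/mL, a value that sits within the scatter of the numbers for both compound 1 and compound 3, so no order among the three can be read from these data.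

Compound 4 `Cc1ccc2c(CSc3nnc(CSc4nc5cc(Cl)ccc5o4)o3)cc(=O)oc2c1` has not yet been measured. It stands to compound 2 as compound 3 stands to compound 1, through the same change, (chloro in place of hydrogen on an aromatic carbon). Because the measured step of a 1.2-fold lower number from compound 1 to compound 3 (0.08 log units; within the scatter) stayed within the scatter, the step of a 1.1-fold lower number from compound 2 to compound 4 (0.04 log units; within the scatter) is expected to be of similar size. On that basis compound 4 is estimated to give about 45 ug/mL in this assay, most likely between 25 ug/mL and 90 ug/mL.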

Compound 4, half-maximal inhibitory concentration: 27.7 ug/mL
Beside the measured number, compound 4's estimate is 1.6-fold (0.21 log units) above it; measured number inside the range.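

In this assay, chloro in place of hydrogen on the core of compound 2 gives a 1.8-fold lower number from compound 2 to compound 4 (0.26 log units; within the scatter). Set beside the same change on the core of compound 1, this step does not differ from the earlier one by more than repeated measurements would allow: the same change on two cores in this assay, a 1.2-fold lower number (0.08 log units; within the scatter) from compound 1 to compound 3 and a 1.8-fold lower number (0.26 log units; within the scatter) from compound 2 to compound 4, 1.5-fold (0.18 log units) apart, within the scatter of two such steps. The two results fit a change that carries over from one core to the other, but neither step rises above the scatter, so they do not show that chloro has a real effect on this read-out, nor that the two cores truly respond alike.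

The compounds shown hold only hydrogen or chloro at this place, so it stays open what a bromine atom, a methyl group or a methoxy group there would do. Also open, going by these compounds, is whether a larger step would appear with chloro on another carbon of the same six-membered aromatic ring.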